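From methyl to phenyl on the shared core

This account rests on a few compounds, and the source may have more. Where it says the series, first, only, none or still open, it means among the compounds named here.

Compound 1 `CN(C)/C=C/C(=O)c1nn(-c2ccccc2)c(-c2ccccc2)c1C#N`: 98800 nM
Compound 2 `Cc1nnc(-c2nn(-c3ccccc3)c(-c3ccccc3)c2C#N)c2cn(-c3ccccc3)nc12`: 96800 nM

Both numbers come from a functional assay on OVCAR-3 cells (Homo sapiens) for inhibition, read by sulforhodamine B assay, with a stated time of 48 h (a lower number here means a stronger inhibitor of growth, a higher number a weaker inhibitor of growth), and lie within the scatter of each other, so neither compound can be ranked above the other. On the data at hand, compound 2 stands level with compound 1. Compound 3 `N#Cc1c(-c2nnc(-c3ccccc3)c3nn(-c4ccccc4)cc23)nn(-c2ccccc2)c1-c1ccccc1` carries phenyl in place of methyl on an aromatic carbon and is otherwise the same as compound 2. The swap sits on an aromatic carbon of a six-membered aromatic ring with 2 nitrogen, part of a fused or bridged system of two rings.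

Among the measured compounds shown here, no two measured compounds differ in one place alone, so nothing shows directly what this swap does in this assay and no shift beyond the scatter is expected. That expectation rests on compound 1 at 98800 nM and compound 2 at 96800 nM giving matching numbers despite their different structures. The estimated step of a 1.1-fold lower number from compound 2 to compound 3 (0.06 log units; within the scatter) is expected to stay within the scatter. For compound 3 the estimate is 85000 nM with an expected range from 35000 nM to 110000 nM.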

Compound 3, concentration for 50% growth inhibition: 93800 nM
Compound 3: the middle estimate sits 1.1-fold (0.04 log units) below what was measured; low and high end bracket the measured number.
By their numbers in this assay, from the lowest: compounds 3, 2 and 1 (each within the scatter of the next).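

In this assay, among the compounds shown here, phenyl in place of methyl on an aromatic carbon gives a 1.0-fold lower number from compound 2 to compound 3 (0.01 log units; within the scatter), the first direct reading of a single change. At this position, on an aromatic carbon of a six-membered aromatic ring with 2 nitrogen, part of a fused or bridged system of two rings, methyl and phenyl therefore cannot be told apart in this assay, even though phenyl brings a whole six-membered aromatic ring of carbon only where methyl has a single carbon. The data offer no explanation for why this exchange leaves the reading level.

This single pair leaves open whether the position is indifferent to substitution in general, since an amine, a carboxylic acid, a methoxy group or a longer chain at the same carbon could still shift the number beyond the scatter. It also leaves open whether phenyl and methyl would remain level on this carbon if another part of the shared core were changed, or in growth assays on other cell lines.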